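This account rests on a few compounds, and the source may have more. Where it says the series, first, only, none or still open, it means among the compounds named here.

Compound 3 `COc1ccc(NC(=O)COc2c(-c3ccccc3)oc3ccccc3c2=O)cc1` is the only one of the three measured compounds that yields an actual number in a functional assay on NCI-H661 cells (Homo sapiens) for antiproliferative activity, read by MTT assay, with a stated time of 72 h; a higher number here means a weaker inhibitor of growth, a lower number a stronger inhibitor of growth: there compound 3 gives 6740 nM. Compound 1 `O=C(COc1c(-c2ccccc2)oc2ccccc2c1=O)Nc1ccccc1` gives > 10000 nM, which is a limit of the assay rather than a number. Compound 2 `O=C(COc1c(-c2ccccc2)oc2ccccc2c1=O)Nc1ccc(F)cc1` gives > 10000 nM, also a limit. Compound 4 `O=C(COc1c(-c2ccccc2)oc2ccccc2c1=O)Nc1ccc(-c2ccccc2)cc1` has not been measured; it differs from compound 3 by phenyl in place of methoxy on an aromatic carbon. The measured steps are an at least 1.4-fold lower number from compound 1 to compound 3 (0.17 log units; that floor lies within the scatter) and an at least 1.4-fold lower number from compound 2 to compound 3 (0.17 log units; that floor lies within the scatter), both floors inside the scatter, while a step that the two limits leave unreadable from compound 1 to compound 2 cannot be read. None of them involves a phenyl entering, so they give no direction for this change. The expected step is a 1.3-fold lower number from compound 3 to compound 4 (0.13 log units; within the scatter). Compound 4 is therefore estimated at 5000 nM, within a range from 1500 nM to 15000 nM.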

Compound 4, concentration for 50% growth inhibition: > 10000 nM
Compound 4 ended at the assay's limit; the forecaster's own chance of this, stated with the estimate: 40%; middle value at least 2.0-fold (0.30 log units) away from the limit.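

With phenyl in place of methoxy, para to a large group, this assay shows an at least 1.4-fold higher number from compound 3 to compound 4 (0.17 log units; that floor lies within the scatter), so this first added ring at the position does not lower the number. The steps from compound 1 and compound 2 to compound 4 cannot be read, as both ends of each are limits. Most of the series therefore gives no number to compare: the limit of > 10000 nM in this assay, at which 3 of the 4 values shown sit.

As far as these compounds go, whether an amine or a carboxylic acid at this position would give a clear number remains open, as does how far the methoxy of compound 3 truly differs from hydrogen.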